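The compounds below may be only part of what the source reports. "The series", "measured", "known", "first", "only" and "open" are said of these compounds alone.

Compound 1 `COc1ccc(C2(c3nc4c(C(F)(F)F)cccc4c(C(=O)O)c3O)CC2)cc1` gives 26% in an assay on isolated protein for inhibition of P-selectin glycoprotein ligand 1 (Homo sapiens), read by surface plasmon resonance, tested at 250 uM; a higher number here means more inhibition at the concentration tested (going by the name of the read-out), a lower number less inhibition.
Compound 2 `CC(Cc1ccccc1)c1nc2c(C(F)(F)F)cccc2c(C(=O)O)c1O` gives 49% in this assay.
Compound 3 `Cc1cc(C(F)(F)F)c2nc(C3(c4ccccc4)CC3)c(O)c(C(=O)O)c2c1` gives 40% in this assay.

Of the compounds shown here, three have been measured so far, all sharing the same core and all carrying a trifluoromethyl group on it. Compound 3 stands second highest of the three numbers. Its nearest neighbour is compound 2, whose number is higher by an amount that lies within the usual scatter of this kind of measurement, so the two cannot be told apart. Its furthest is compound 1, whose number is lower by an amount beyond the scatter, so compound 3 does show more inhibition than compound 1.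

Compound 4 `CCc1cc(C(F)(F)F)c2nc(C3(c4ccccc4)CC3)c(O)c(C(=O)O)c2c1` has not been measured. It differs from compound 3 in one place: methyl in place of hydrogen on a saturated chain carbon bound to an aromatic carbon. Seen one bond further out, the same difference reads methyl to ethyl. Within the data shown here, no pair of measured compounds differs by this change, so there is no measured step to lean on. A change this small, adding a single carbon to a short chain on the core, is expected to move this assay little, if at all beyond the scatter, in either direction. Compound 4 is therefore estimated at 40%, with a range from 28% to 52%, which means an expected step of no change at the digits printed from compound 3 to compound 4 (within the scatter).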

Compound 4, a percentage reported as inhibition, at one concentration (the size of the read-out at that concentration, not a potency): 40%
Compound 4: middle estimate and measured number agree at the digits printed; measured number inside the range.
By their numbers in this assay, from the lowest: compound 1; then compounds 3, 4 and 2 (each within the scatter of the next).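

In this assay the change from methyl to ethyl, a methyl in place of hydrogen on a saturated chain carbon bound to an aromatic carbon, gives no change at the digits printed from compound 3 to compound 4 (within the scatter). Among these compounds, this is the first pair that differs in one place only, so for the first time a single change can be read without other differences in the structure getting in the way, and at this place one added carbon leaves the inhibition at the concentration tested indistinguishable. Nothing measured on these compounds explains this result.

On these data alone, a single step shows only that ethyl can stand in for methyl here, so it remains open whether a longer chain such as propyl or butyl, or a different group such as an amine or a carboxylic acid on the same carbon, would shift the number beyond the scatter. As far as these compounds go, the step also comes from a single pair with a phenyl-bearing cyclopropane on the shared core, and it remains open whether the same change would read the same way alongside the other side chains seen.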